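Aryl swap on the ring amine across two cores

A few compounds are considered here, and "the series" means these few. Any claim that something is new, unique, unknown or untested is made for them only; others in the source may bear on it.

Compound 1 `Cc1ccc(-c2nnc(N3CCN(C(=O)CN4CCN(c5cccc(Cl)c5)CC4)CC3)nc2-c2ccc(C)cc2)cc1` and compound 2 `COc1ccc(N2CCN(CC(=O)N3CCN(c4nnc(-c5ccc(C)cc5)c(-c5ccc(C)cc5)n4)CC3)CC2)cc1` share one core and differ in a single place: 4-methoxyphenyl in place of 3-chlorophenyl on an amine nitrogen in a ring. In a functional assay on MCF7 cells (Homo sapiens) for cytotoxicity, read by MTT assay, with a stated time of 24 h (a lower number here means a stronger inhibitor, a higher number a weaker inhibitor), compound 1 gives 797000 nM, and compound 2 gives 53000 nM. The step is a 15-fold lower number from compound 1 to compound 2 (1.18 log units; beyond the scatter), so on this core the exchange cuts the number well beyond the usual scatter.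

Compound 3 `COc1ccc(-c2nnc(N3CCN(C(=O)CN4CCN(c5cccc(Cl)c5)CC4)CC3)nc2-c2ccc(OC)cc2)cc1` carries a different core; how its core differs from that of compound 1 is not broken down here. In this assay compound 3 reaches only a limit, > 814000 nM, which is the limit of the method rather than a number, (the limit of > 814000 nM in this assay, at which 1 of the 3 values shown sits).

Compound 4 `COc1ccc(-c2nnc(N3CCN(C(=O)CN4CCN(c5ccc(OC)cc5)CC4)CC3)nc2-c2ccc(OC)cc2)cc1` is compound 3 with the same change applied: 4-methoxyphenyl in place of 3-chlorophenyl on an amine nitrogen in a ring. The place line reads word for word as for the pair above, so this is the same change, made twice among the compounds shown. Whether it acts on the core of compound 3 as it did on the core of compound 1 is not known, and with compound 3 at a limit the starting point is itself uncertain; the expectation rests only on the measured step of a 15-fold lower number from compound 1 to compound 2 (1.18 log units; beyond the scatter). The step from compound 3 to compound 4 is expected to be about an at least 4.0-fold lower number from compound 3 to compound 4 (0.60 log units; beyond the scatter). Compound 4 in this assay is therefore estimated at 200000 nM, with a likely span from 40000 nM to 900000 nM, and a real chance that the measurement again ends at a limit.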

Compound 4, half-maximal inhibitory concentration: > 821000 nM
Compound 4: a limit, no number (the forecaster's own chance of this, stated with the estimate: 35%); at least 4.1-fold (0.61 log units) between middle value and limit.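

In this assay compound 3 and compound 4 both end at a limit rather than a number, so the step between them cannot be read, and the exchange of 3-chlorophenyl for 4-methoxyphenyl gives no second measured size. From the compounds shown here alone, what stays open is whether this exchange lowers the number on the core of compound 3 as it did on the core of compound 1.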